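From acetamido to iodo at one chain carbon

The compounds below may be only part of what the source reports. "The series", "measured", "known", "first", "only" and "open" are said of these compounds alone.

In an ADME assay on L6 cells (Rattus norvegicus) for inhibition, read by resazurin assay, with a stated time of 72 h (a higher number here means a weaker inhibitor, a lower number a stronger inhibitor), compound 1 (`CSC[C@H]1O[C@@H](n2cnc3c(N)nc(Cl)nc32)[C@H](OC(C)=O)[C@@H]1OC(C)=O`) gives 216000 nM as its reading, compound 2 (`CC(=O)O[C@@H]1[C@H](OC(C)=O)[C@@H](CS(C)(=O)=O)O[C@H]1n1cnc2c(N)nc(Cl)nc21`) gives 114000 nM and compound 3 (`CC(=O)NC[C@H]1O[C@@H](n2cnc3c(N)nc(Cl)nc32)[C@H](OC(C)=O)[C@@H]1OC(C)=O`) gives 190000 nM on the same scale. These three share a core and differ only in the group on a saturated chain carbon bound to a saturated ring carbon. Compound 3 stands within the usual scatter of both other compounds, so these numbers do not separate it from them.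

Compound 4 (`CC(=O)O[C@@H]1[C@H](OC(C)=O)[C@@H](CI)O[C@H]1n1cnc2c(N)nc(Cl)nc21`) has iodo in place of acetamido at that same carbon (iodo in place of acetamido on a saturated chain carbon bound to a saturated ring carbon) and has not yet been measured. Three measured swaps at this carbon bear on the change: there is a 1.9-fold lower number from compound 1 to compound 2 (0.28 log units; within the scatter) for methylsulfonyl replacing methylsulfanyl, a 1.1-fold lower number from compound 1 to compound 3 (0.06 log units; within the scatter) for acetamido replacing methylsulfanyl, and a 1.7-fold higher number from compound 2 to compound 3 (0.22 log units; within the scatter) for acetamido replacing methylsulfonyl. All three stay within the scatter, but none involves iodo, so they offer only indirect guidance. Resting on these steps, no shift beyond the scatter is expected in this assay for this swap. The estimated change is a 1.3-fold lower number from compound 3 to compound 4 (0.10 log units; within the scatter) and nothing larger is expected from these data. For compound 4 the estimated value is 150000 nM with an expected range from 60000 nM to 300000 nM in this measurement.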

Compound 4, half-maximal inhibitory concentration: 86000 nM
Estimate against measurement, compound 4: 1.7-fold (0.24 log units) above; the range from low to high includes it.
By their numbers in this assay, from the lowest: compounds 4, 2, 3 and 1 (each within the scatter of the next, the first and the last beyond it).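

Among the groups shown on this saturated chain carbon bound to a saturated ring carbon, only iodo gives steps beyond the scatter in this assay, with a 2.2-fold lower number from compound 3 to compound 4 (0.34 log units; beyond the scatter) and a 2.5-fold lower number from compound 1 to compound 4 (0.40 log units; beyond the scatter), both modest in size. Going by these compounds alone, the swaps among methylsulfanyl, methylsulfonyl and acetamido had all stayed within the scatter, so these two steps are the first sign that the group at this carbon can shift the reading by a measurable amount, even if only slightly. The separation is only partial, though: with a 1.3-fold lower number from compound 2 to compound 4 (0.12 log units; within the scatter), also within the scatter, iodo and methylsulfonyl cannot be told apart, so the change from acetamidomethyl to iodomethyl does not set iodo apart from every other group here.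

From the compounds shown here alone, it remains open how an amine, a carboxylic acid, a longer chain or another halogen such as bromo would read at this same carbon, and whether any of them would produce a larger step. Nothing among the data shown gives a measured reason for the steps involving iodo.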